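Aryl urea series: terminal ring swap from compound 2 to compound 4

The source may hold more compounds than are shown below. What is called first, only, known or untested is meant among the compounds shown, and "the series" means these compounds.

Three ureas sharing one core have been measured in a functional assay on MDA-MB-231 cells (Homo sapiens) for inhibition, read by MTT assay and WST assay, with a stated time of 72 h; a higher number here means a weaker inhibitor, a lower number a stronger inhibitor. Compound 1 `O=C(Nc1ccc(Oc2ccc(-c3nccs3)cc2)cc1)Nc1ccc(Cl)c([N+](=O)[O-])c1` gives 6870 nM. Compound 2 `O=C(Nc1ccc(Oc2ccc(-c3nccs3)cc2)cc1)Nc1ccc(F)c(C(F)(F)F)c1` gives 8660 nM, and compound 3 `O=C(Nc1ccc(Oc2ccc(-c3nccs3)cc2)cc1)Nc1cc(C(F)(F)F)ccc1Cl` gives 8900 nM. Compound 2 stands among the three numbers with compound 3 as its nearest neighbour and compound 1 as its furthest, every gap lying within the scatter: a 1.3-fold higher number from compound 1 to compound 2 (0.10 log units; within the scatter), a 1.3-fold higher number from compound 1 to compound 3 (0.11 log units; within the scatter) and a 1.0-fold higher number from compound 2 to compound 3 (0.01 log units; within the scatter).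

Compound 4 `O=C(Nc1ccc(Oc2ccc(-c3nccs3)cc2)cc1)Nc1cc(Br)cc(C(F)(F)F)c1` is not yet measured. Its change from compound 2 is 3-bromo-5-(trifluoromethyl)phenyl in place of 4-fluoro-3-(trifluoromethyl)phenyl on an amide-type nitrogen.

All three measured steps exchange one substituted phenyl for another on the same amide-type nitrogen, and none of them moved the number beyond the scatter. The change to compound 4 is of the same kind, so no step beyond the scatter is expected in this assay in either direction. For compound 4 the estimate in this assay is 8500 nM, with a range from 4000 nM to 18000 nM. This estimate means an expected step of a 1.0-fold lower number from compound 2 to compound 4 (0.01 log units; within the scatter).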

Compound 4, half-maximal inhibitory concentration: 4190 nM
Beside the measured number, compound 4's estimate is 2.0-fold (0.31 log units) above it; the range from low to high includes it.
By their numbers in this assay, from the lowest: compounds 4, 1, 2 and 3 (each within the scatter of the next, the first and the last beyond it).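

In this assay, exchanges at this terminal ring on the amide-type nitrogen now produce steps beyond the scatter, both modest (a 2.1-fold lower number from compound 2 to compound 4 (0.32 log units; beyond the scatter); a 2.1-fold lower number from compound 3 to compound 4 (0.33 log units; beyond the scatter)). The 3-bromo-5-(trifluoromethyl)phenyl ring of compound 4 does not separate from the 4-chloro-3-nitrophenyl ring of compound 1 (a 1.6-fold lower number from compound 1 to compound 4 (0.21 log units; within the scatter)), so the position distinguishes it from only two of the three earlier rings. No supporting data bear on the origin of these steps.

On these data alone, whether the bromine carries the step remains open, as does whether a nitrile, a methoxy group or an amine in its place would keep the number of compound 4. As far as these compounds go, the shared core is the same in all four compounds, so the effect of any change outside this terminal ring also remains open.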